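Trifluoromethyl in Place of Methyl in a Flat Series

The compounds below may be only part of what the source reports. "The series", "measured", "known", "first", "only" and "open" are said of these compounds alone.

Three compounds share one core. Compound 3 `Cc1ccc(-n2cc(CNC(=O)c3cccc4c3cnn4C(C)C)nn2)cc1` gives only a limit in a functional assay on MGC-803 cells (Homo sapiens) for inhibition, read by MTT assay, with a stated time of 72 h (on this read-out lower numbers stand for stronger inhibition and higher numbers for weaker inhibition), namely > 40000 nM. Compound 1 `CC(C)n1ncc2c(C(=O)NCc3cn(-c4cccc(F)c4)nn3)cccc21` likewise sits at a limit, > 40000 nM. Compound 2 `CC(C)n1ncc2c(C(=O)NCc3cn(-c4ccc([N+](=O)[O-])cc4)nn3)cccc21` also gives a limit, > 40000 nM. The steps a step that the two limits leave unreadable from compound 1 to compound 2, a step that the two limits leave unreadable from compound 1 to compound 3 and a step that the two limits leave unreadable from compound 2 to compound 3 therefore cannot be sized, as the limit of > 40000 nM in this assay, at which 3 of the 3 values shown sit, shows. Compound 4 `CC(C)n1ncc2c(C(=O)NCc3cn(-c4ccc(C(F)(F)F)cc4)nn3)cccc21` differs from compound 3 by trifluoromethyl in place of methyl on an aromatic carbon. For the measured compounds named here, none of the measured steps can be read, so no direction beyond the scatter is expected from this change; compound 3 stands at the limit, as do the other two. Compound 4 is therefore expected to remain at that same limit, an expected step of a number no higher from compound 3 to compound 4 (the limit leaves the size open), with an estimate of 40000 nM between 15000 nM and 100000 nM.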

Compound 4, half-maximal inhibitory concentration: > 40000 nM
Compound 4 ended at the assay's limit; the forecaster's own chance of this, stated with the estimate: 85%; the middle value sits exactly at the limit.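

The steps linking compound 4 with compound 1, compound 2 and compound 3 cannot be read, because all four compounds give only a limit: the limit of > 40000 nM in this assay, at which 4 of the 4 values shown sit.

The compounds shown leave open whether changing the group on the phenyl ring affects inhibition at all.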